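Swapping isopropoxy for (methylsulfonyl)oxy on a shared core

This account rests on a few compounds, and the source may have more. Where it says the series, first, only, none or still open, it means among the compounds named here.

In a functional assay on P388 cells (Mus musculus) for cytotoxicity (a higher number here means that more compound is needed for the effect, a lower number that less compound is needed), compound 1 (`CC(C)Oc1cc(-c2ccccc2)nc2ccccc12`) reads > 10 ug/mL, which is a limit of the assay and not a number. It is the only one of the three measured compounds at that limit (the limit of > 10 ug/mL in this assay, at which 1 of the 3 values shown sits). Compound 2 (`Oc1cc(-c2ccccc2)nc2ccc(Cl)cc12`) gives 0.84 ug/mL in this assay, and compound 3 (`Oc1cc(-c2ccccc2)nc2cc(F)ccc12`) gives 0.29 ug/mL there. Among the measured compounds shown here, both differ from compound 1 in more than one place, so no measured pair isolates the change at hand. Compound 4 (`CS(=O)(=O)Oc1cc(-c2ccccc2)nc2ccccc12`) carries methylsulfonyl in place of isopropyl on an oxygen on an aromatic ring. A small move towards less compound being needed is expected, though it may not exceed the scatter. The expected step is an at least 1.6-fold lower number from compound 1 to compound 4 (0.22 log units; that floor lies within the scatter). Compound 4 is estimated at 6 ug/mL (expected range 1 ug/mL to 25 ug/mL).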

Compound 4, half-maximal effective concentration: > 10 ug/mL
Compound 4: no number, only a limit; the forecaster's own chance of this, stated with the estimate: 40%; middle value at least 1.6-fold (0.22 log units) away from the limit.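

In this assay, compound 1 and compound 4 both stand at a limit and not at a number, so no step between them can be read: the limit of > 10 ug/mL in this assay, at which 2 of the 4 values shown sit.

The compounds shown leave open whether (methylsulfonyl)oxy in place of isopropoxy on the shared core changes the amount of compound needed at all.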